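The source may hold more compounds than are shown below. What is called first, only, known or untested is meant among the compounds shown, and "the series" means these compounds.

Compound 1 `Nc1cccc2c(-c3cccc(NC(=O)c4ccc(Cl)c(C(F)(F)F)c4)c3)ccnc12` and compound 2 `COc1ccc(C(=O)Nc2cccc(-c3ccnc4c(NC(C)=O)cccc34)c2)cc1OC` share the same core and differ in the amide-linked aryl group and in the substituent on the core. In a functional assay on LOX IMVI cells (Homo sapiens) for antiproliferative activity, read by sulforhodamine B assay, with a stated time of 48 h (a higher number here means a weaker inhibitor, a lower number a stronger inhibitor), compound 1 gives 3200 nM. In this assay compound 2 gives 800 nM, the lower of the two numbers, and the gap between the two values lies beyond the usual scatter. Compound 3 `CC(=O)Nc1cccc2c(-c3cccc(NC(=O)c4ccc5c(c4)OCCO5)c3)ccnc12` has not yet been measured. It differs from compound 2 in one place: 2,3-dihydro-1,4-benzodioxin-6-yl in place of 3,4-dimethoxyphenyl on a carbonyl carbon. The two oxygen atoms remain on the same aromatic ring and are joined by a two-carbon bridge into a non-aromatic ring, so the counts of heavy atoms, donors and acceptors do not change. Among the measured compounds shown here, no measured pair shows this change, so no step can be read from the data. Compound 3 is therefore expected to stay close to compound 2, with a step of a 1.1-fold higher number from compound 2 to compound 3 (0.05 log units; within the scatter) that should lie within the scatter. The estimate for compound 3 in this assay is 900 nM, with a range from 400 nM to 2200 nM.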

Compound 3, half-maximal inhibitory concentration: 96 nM
The estimate for compound 3 lay 9.4-fold (0.97 log units) above the measured number, outside the stated range (below it).
By their numbers in this assay, from the lowest: compound 3; then compound 2; then compound 1.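

In this assay, closing the two oxygen atoms of 3,4-dimethoxyphenyl into 2,3-dihydro-1,4-benzodioxin-6-yl on a carbonyl carbon gives an 8.3-fold lower number from compound 2 to compound 3 (0.92 log units; beyond the scatter) and thus a step beyond the scatter. The pair of compound 1 and compound 2 differed in two places and could not isolate this group, whereas here a single change with the same counts of heavy atoms, donors and acceptors moves the number, so those counts alone do not settle activity at this position. The data shown give no measured basis for explaining this step.

From the compounds shown here alone, whether the lower number requires this six-membered ring stays open, as a five-membered methylenedioxy ring or a single methoxy group would test that. Going by these compounds, it also remains open whether the step carries over when the acetamide on the core is replaced by a free amine.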